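The compounds below may be only part of what the source reports. "The series", "measured", "known", "first", "only" and "open" are said of these compounds alone.

Of the compounds shown here, three have so far been measured in a functional assay on HL-60 cells (Homo sapiens) for inhibition, read by MTT assay, with a stated time of 72 h; a higher number here means a weaker inhibitor, a lower number a stronger inhibitor. Compound 1 `CCc1nc(-c2cccc(F)c2)c(C(=O)N2CCN(c3cccc(OC)c3)CC2)o1` gives 201 nM in this assay. Compound 2 `Cc1nc(-c2ccccc2)c(C(=O)N2CCN(c3c(C)cccc3C)CC2)o1` gives 146 nM in this assay. Compound 3 `CCc1nc(-c2cccc(F)c2)c(C(=O)N2CCN(c3cccc(Cl)c3)CC2)o1` gives 317 nM in this assay, the highest of the three numbers; compound 1 is its nearest neighbour, within the scatter, and compound 2 its furthest, with a gap that lies beyond the scatter. Among the measured compounds shown here, the only single-point step among the measured compounds, a 1.6-fold higher number from compound 1 to compound 3 (0.20 log units; within the scatter), stays within the scatter.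

Compound 4 `CCc1nc(-c2ccc(F)cc2)c(C(=O)N2CCN(c3cccc(Cl)c3)CC2)o1` has not yet been measured. It differs from compound 3 in one place: 4-fluorophenyl in place of 3-fluorophenyl on an aromatic carbon. For the measured compounds named here, no measured step touches this part of the molecule: the step from compound 1 to compound 3 altered a different ring, and compound 2 differs from compound 3 in several places at once, so its number gives no clean comparison. With nothing in the data pointing in either direction, the expected step of a 1.0-fold higher number from compound 3 to compound 4 (0.00 log units; within the scatter) is none beyond the scatter. Compound 4 is therefore estimated at 320 nM in this assay, with a range from 150 nM to 700 nM.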

Compound 4, half-maximal inhibitory concentration: 169 nM
The estimate for compound 4 lay 1.9-fold (0.28 log units) above the measured number, and the stated range covers the measured number.
By their numbers in this assay, from the lowest: compounds 2, 4, 1 and 3 (each within the scatter of the next, the first and the last beyond it).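

In this assay, the exchange of 3-fluorophenyl for 4-fluorophenyl on the aromatic carbon of the five-membered ring is the first change shown at this position, and it gives a 1.9-fold lower number from compound 3 to compound 4 (0.27 log units; within the scatter); the two isomers, which have the same atoms joined differently, therefore cannot be told apart in this assay. Together with the chloro for methoxy change on a different ring, a 1.6-fold higher number from compound 1 to compound 3 (0.20 log units; within the scatter), this means that both single-place changes among these compounds stay within the scatter, so neither of them yet marks a place where a change clearly alters the number. Among the compounds shown here, no supporting measurement bears on this result, so the data offer no account of the step.

On these data alone, compound 2 carries an unsubstituted phenyl at this position but differs from the others in several places at once, so what the fluorine itself does to the number remains open. It is also open whether this position would tolerate a quite different substituent on the phenyl ring, such as a carboxylic acid or an aminomethyl group, since fluorine is the only substituent shown there.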